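The source may report more compounds than this note shows. Statements on the series, on what has been measured and on what is new or still open speak of the compounds shown alone.

The measured compounds:

Compound 1, `O[C@@H](c1ccccc1)[C@H]1CO[C@H](c2ccccc2)[C@@H](C/C=C/c2ccccc2)C1` — 7040 nM in a functional assay on HL-60 cells (Homo sapiens) for cytotoxicity, read by WST assay, with a stated time of 48 h; a lower number here means a stronger inhibitor, a higher number a weaker inhibitor.
Compound 2, `Oc1ccccc1/C=C/C[C@H]1C[C@@H]([C@@H](O)c2ccccc2)CO[C@@H]1c1ccccc1` — 10800 nM in this assay.
Compound 3, `O[C@@H](c1ccccc1)[C@H]1CO[C@H](c2ccccc2)[C@@H](C/C=C/c2cccnc2)C1` — > 100000 nM in this assay, which is a limit of the assay rather than a number.

Among the two compounds with a number, compound 1 gives the lowest value, and its nearest neighbour is compound 2, with a 1.5-fold higher number from compound 1 to compound 2 (0.19 log units; within the scatter). Compound 3 stands at the limit of > 100000 nM in this assay, at which 1 of the 3 values shown sits, in that assay.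

Compound 4, `O=[N+]([O-])c1ccccc1/C=C/C[C@H]1C[C@@H]([C@@H](O)c2ccccc2)CO[C@@H]1c1ccccc1`, has not yet been measured in this assay. It differs from compound 1 by nitro in place of hydrogen on an aromatic carbon. For the measured compounds named here, the closest measured step is the one from compound 1 to compound 2, where a hydroxy entered on an aromatic carbon with a 1.5-fold higher number from compound 1 to compound 2 (0.19 log units; within the scatter). The steps leading to compound 3, an at least 14-fold higher number from compound 1 to compound 3 (1.15 log units; beyond the scatter) and an at least 9.2-fold higher number from compound 2 to compound 3 (0.96 log units; beyond the scatter), replaced the phenyl ring itself with pyridin-3-yl and are of a different kind. A nitro in place of hydrogen on the aromatic carbon is therefore expected to leave the number close to that of compound 1, with at most a small rise. For compound 4 the estimate in this assay is 9000 nM, between 3000 nM and 40000 nM, which is expected to mean a 1.3-fold higher number from compound 1 to compound 4 (0.11 log units; within the scatter).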

Compound 4, half-maximal inhibitory concentration: 7250 nM
Beside the measured number, compound 4's estimate is 1.2-fold (0.09 log units) above it; low and high end bracket the measured number.
By their numbers in this assay, from the lowest: compounds 1, 4 and 2 (each within the scatter of the next). At a limit, above all of these: compound 3.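

In this assay, the aromatic carbon ortho to a large group now holds three different occupants, hydrogen, hydroxy and nitro, and their numbers all lie within the scatter of one another: a 1.0-fold higher number from compound 1 to compound 4 (0.01 log units; within the scatter), and a 1.5-fold lower number from compound 2 to compound 4 (0.17 log units; within the scatter). Nitro brings 3 heavy atoms, 0 hydrogen-bond donors and 2 hydrogen-bond acceptors to this place, so compound 2's result at this position does not depend on a hydroxy, and the place accepts a group of more than one heavy atom. The one large difference involving compound 4 is to the compound with the pyridin-3-yl ring, an at least 13-fold lower number from compound 3 to compound 4 (1.13 log units; beyond the scatter), so among these compounds the separation follows the replacement of the ring itself, not the two substituents placed on the phenyl. Compound 3 stays at a limit of the assay and not at a number: the limit of > 100000 nM in this assay, at which 1 of the 4 values shown sits.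

As far as these compounds go, whether an amine or a carboxylic acid on the same aromatic carbon would also stay within the scatter of compound 1 remains open. So does the effect of a longer chain in place of the double-bonded chain that carries the ring.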